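This account rests on a few compounds, and the source may have more. Where it says the series, first, only, none or still open, it means among the compounds named here.

Of the compounds shown here, three have been measured so far in a functional assay on ECa-109 cells for inhibition, with ECa-109 cell line (Homo sapiens) as the target, read by MTT assay, with a stated time of 48 h; on this read-out lower numbers stand for stronger inhibition and higher numbers for weaker inhibition. Compound 2 (`COc1ccc(-c2coc3cc(OCCCSC(=S)N4CCN(C)CC4)ccc3c2=O)cc1`) reads 24200 nM and compound 3 (`COc1ccc(-c2coc3cc(OCCCSC(=S)N4CCN(Cc5ccccc5)CC4)ccc3c2=O)cc1`) reads 25300 nM, so these two lie within the scatter of each other at the top of the range. Compound 1 (`COc1ccc(-c2coc3cc(OCCCCSC(=S)N4CCN(C(=O)OC(C)(C)C)CC4)ccc3c2=O)cc1`) reads 8840 nM, a number clearly lower than that of compound 2.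

The next compound, compound 4 (`COc1ccc(-c2coc3cc(OCCCSC(=S)N4CCCC4)ccc3c2=O)cc1`), departs from compound 2 at a single place, with pyrrolidin-1-yl in place of 4-methylpiperazin-1-yl on a thiocarbonyl carbon. Within the data shown here, only one measured step bears on this part of the molecule. It is a 1.0-fold higher number from compound 2 to compound 3 (0.02 log units; within the scatter), with phenyl in place of hydrogen on a saturated chain carbon bound to an amine nitrogen in a ring, and it shows that this change left the number within the scatter. That step leaves the ring itself in place, however, so it is only a loose guide. Compound 1 differs from compound 2 in more than one place, and its value cannot be tied to any single change.

No step beyond the scatter is therefore expected, and the estimated step is a 1.5-fold lower number from compound 2 to compound 4 (0.18 log units; within the scatter) in this assay. For compound 4 the expected value is 16000 nM, with an estimated range from 6000 nM to 40000 nM as the outcome.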

Compound 4, half-maximal inhibitory concentration: 30800 nM
The estimate for compound 4 lay 1.9-fold (0.28 log units) below the measured number; low and high end bracket the measured number.
By their numbers in this assay, from the lowest: compound 1; then compounds 2, 3 and 4 (each within the scatter of the next).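

In this assay, the exchange of 4-methylpiperazin-1-yl for pyrrolidin-1-yl on the thiocarbonyl carbon gives a 1.3-fold higher number from compound 2 to compound 4 (0.10 log units; within the scatter). The earlier step between compounds that differ in one place, a 1.0-fold higher number from compound 2 to compound 3 (0.02 log units; within the scatter), left the six-membered ring in place, whereas this one replaces the whole group: a six-membered non-aromatic ring with 2 hetero atoms gives way to a five-membered non-aromatic ring with 1 hetero atom. At this position, then, neither the ring size nor the second ring nitrogen with its methyl group has yet been seen to move the number beyond the scatter, as far as this single exchange can show, and no independent measurement is available to explain that result.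

The compounds shown leave open whether piperidin-1-yl, morpholin-4-yl or an open-chain diethylamino group on the thiocarbonyl carbon would also stay within the scatter of compound 2. They also leave open what a longer chain does with pyrrolidin-1-yl in place, since compound 1 differs from the others in more than one place and its value cannot be tied to the chain alone.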